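A few compounds are considered here, and "the series" means these few. Any claim that something is new, unique, unknown or untested is made for them only; others in the source may bear on it.

In an ADME assay on Vero cells (Chlorocebus sabaeus) for cytotoxicity, read by MTT assay, with a stated time of 72 h (on this read-out lower numbers stand for higher toxicity in this test and higher numbers for lower toxicity in this test), compound 1 `COC(=O)c1cc(-c2cccc(NC(=O)c3ccc(C4OC4C(=O)c4ccc(Cl)cc4)cc3)c2)on1` reaches only the limit of > 20 ug/mL, a boundary of the test rather than a number. Compound 2 `CCOc1ccc(C(=O)/C=C/c2ccc(C(=O)Nc3cccc(-c4cc(C(=O)OC)no4)c3)cc2)cc1` likewise stops at the limit of > 40 ug/mL. Compound 1 therefore stands among values that are limits only, as shown by the limit of > 20 ug/mL in this assay, at which 1 of the 2 values shown sits, and (the limit of > 40 ug/mL in this assay, at which 1 of the 2 values shown sits). Compound 3 `COC(=O)c1cc(-c2cccc(NC(=O)c3ccc(/C=C/C(=O)c4ccc(C)c(F)c4)cc3)c2)on1` differs from compound 1 by 2-((3-fluoro-4-methylphenyl)carbonyl)ethenyl in place of 3-((4-chlorophenyl)carbonyl)oxiran-2-yl on an aromatic carbon. Among the measured compounds shown here, with no measured step to lean on, the step that the limit leaves unreadable from compound 1 to compound 3 is expected to be none beyond the usual scatter. Compound 3 is accordingly estimated at 30 ug/mL, between 10 ug/mL and 90 ug/mL, and is expected to be reported again only as a limit.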

Compound 3, half-maximal cytotoxic concentration: > 50 ug/mL
Compound 3 gave a limit, no number; the forecaster's own chance of this, stated with the estimate: 70%; at least 1.6-fold (0.22 log units) between middle value and limit.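

Among the compounds shown here, compound 1, compound 2 and compound 3 all stop at limits rather than numbers in this assay, so no step between them can be read. Going by these compounds, the concentration at which each compound becomes toxic to these cells stays open.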